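A few compounds are considered here, and "the series" means these few. Any claim that something is new, unique, unknown or untested is made for them only; others in the source may bear on it.

Compound 1 `O=C(Nc1cccc(-c2oc3cc(-c4ccc(F)cc4)ccc3c(=O)c2O)c1)c1ccc(Br)cc1` gives 13900 nM in a functional assay on HepG2 cells (Homo sapiens) for antiproliferative activity, read by CCK-8 assay, with a stated time of 72 h; on this read-out lower numbers stand for stronger inhibition and higher numbers for weaker inhibition.
Compound 2 `O=C(Nc1cccc(-c2oc3cc(-c4ccc(F)cc4)ccc3c(=O)c2O)c1)c1cccc(F)c1` gives 15500 nM.
Compound 3 `O=C(Nc1cccc(-c2oc3cc(-c4ccc(F)cc4)ccc3c(=O)c2O)c1)c1ccc(Br)cc1F` gives only a limit, > 100000 nM.

Compound 1 holds the lowest of the two numbers, and the step of a 1.1-fold higher number from compound 1 to compound 2 (0.05 log units; within the scatter) shows that swapping the ring on the carbonyl carbon hardly moves the result. Compound 3 sits at the limit of > 100000 nM in this assay, at which 1 of the 3 values shown sits, and the step of an at least 7.1-fold higher number from compound 1 to compound 3 (0.85 log units; beyond the scatter) shows that adding fluoro there costs a good deal. Compound 4 `CCCc1ccc(C(=O)Nc2cccc(-c3oc4cc(-c5ccc(F)cc5)ccc4c(=O)c3O)c2)cc1` differs from compound 1 by propyl in place of bromo on an aromatic carbon. For the measured compounds named here, no measured step exchanges bromo for propyl, but the step from compound 1 to compound 2 suggests that a change to the ring on the carbonyl carbon alone stays within the scatter, so compound 4 is expected to show a 1.1-fold higher number from compound 1 to compound 4 (0.03 log units; within the scatter), estimated at 15000 nM within 6000 nM to 40000 nM.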

Compound 4, half-maximal inhibitory concentration: 51500 nM
The estimate for compound 4 lay 3.4-fold (0.54 log units) below the measured number; measured number above the stated range.
By their numbers in this assay, from the lowest: compounds 1 and 2 (each within the scatter of the next); then compound 4. At a limit, above all of these: compound 3.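

Unlike the earlier swap on the carbonyl carbon, which stayed within the scatter, this position does respond to its group: propyl in place of bromo gives a 3.7-fold higher number from compound 1 to compound 4 (0.57 log units; beyond the scatter), and the comparison with the 3-fluorophenyl group gives a 3.3-fold higher number from compound 2 to compound 4 (0.52 log units; beyond the scatter). The remaining comparison reads as an at least 1.9-fold lower number from compound 3 to compound 4 (0.28 log units; that floor lies within the scatter), so it shows no firm gap. The value for compound 3 is a limit, not a number: the limit of > 100000 nM in this assay, at which 1 of the 4 values shown sits.

Still open, from the compounds shown here alone, is how a methyl, a longer chain such as butyl, or an amine would fare at this position. Going by these compounds, whether the number keeps rising with chain length also remains unknown.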